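Neopentyl homologue of compound 3: cytotoxicity expectation

The compounds below may be only part of what the source reports. "The series", "measured", "known", "first", "only" and "open" are said of these compounds alone.

Compound 3 `Cc1nc2cc(C(=O)NCCC(C)C)nn2c(-c2cc(F)c3c(c2C)CCCO3)c1[C@H](OC(C)(C)C)C(=O)O` carries an isobutyl chain on the amide-type nitrogen. In an ADME assay on MT2 cells (Homo sapiens) for cytotoxicity (on this read-out lower numbers stand for higher toxicity in this test and higher numbers for lower toxicity in this test), compound 3 reports only a limit, > 40000 nM. Compound 1 `CCCc1cc(CNC(=O)c2cc3nc(C)c([C@H](OC(C)(C)C)C(=O)O)c(-c4cc(F)c5c(c4C)CCCO5)n3n2)ccc1F` likewise reaches only a limit in this assay, > 20000 nM. Compound 2 `Cc1nc2cc(C(=O)NCc3ccc(F)c(C4CC4)c3)nn2c(-c2cc(F)c3c(c2C)CCCO3)c1[C@H](OC(C)(C)C)C(=O)O` also gives a limit, > 40000 nM. The steps that touch compound 3 are a step that the two limits leave unreadable from compound 1 to compound 3 and a step that the two limits leave unreadable from compound 2 to compound 3; the remaining step is a step that the two limits leave unreadable from compound 1 to compound 2. All three values sit at limits, the limit of > 20000 nM in this assay, at which 1 of the 3 values shown sits, and (the limit of > 40000 nM in this assay, at which 2 of the 3 values shown sit). Compound 4 `Cc1nc2cc(C(=O)NCCC(C)(C)C)nn2c(-c2cc(F)c3c(c2C)CCCO3)c1[C@H](OC(C)(C)C)C(=O)O` differs from compound 3 by methyl in place of hydrogen on a saturated chain carbon bound to three saturated chain carbons, isobutyl to neopentyl. Within the data shown here, no measured step is readable, so no direction can be taken from the series. Compound 4 is expected to stay at the limit, and a number no higher from compound 3 to compound 4 (the limit leaves the size open) is expected to be no step beyond the scatter. Compound 4 is estimated at 40000 nM, between 20000 nM and 80000 nM.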

Compound 4, half-maximal cytotoxic concentration: > 40000 nM
Compound 4: only a limit was reported; the forecaster's own chance of this, stated with the estimate: 85%; the middle value sits exactly at the limit.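

Among these compounds, compound 4 reports > 40000 nM, a limit, so no step from compound 1, compound 2 or compound 3 to compound 4 can be read. The compounds shown leave open where any actual half-maximal cytotoxic concentration lies, and whether the group on the amide-type nitrogen changes it.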